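Carboxy for nitro across two hydrazone cores

The source may hold more compounds than are shown below. What is called first, only, known or untested is meant among the compounds shown, and "the series" means these compounds.

Compound 1 `Cc1nn(-c2ccccc2)c(Oc2ccc(-c3nc4cc([N+](=O)[O-])ccc4[nH]3)cc2)c1/C=N/Nc1ccccc1` and compound 3 `Cc1nn(-c2ccccc2)c(Oc2ccc(-c3nc4cc(C(=O)O)ccc4[nH]3)cc2)c1/C=N/Nc1ccccc1` share one core and differ only in carboxy in place of nitro on an aromatic carbon. Among the compounds with values here, in a functional assay on MCF7 cells (Homo sapiens) for cytotoxicity, read by sulforhodamine B assay, with a stated time of 48 h (a lower number here means a stronger inhibitor of growth, a higher number a weaker inhibitor of growth), compound 1 gives 12300 nM, and compound 3 gives 17700 nM; the step of a 1.4-fold higher number from compound 1 to compound 3 (0.16 log units; within the scatter) is the only measured instance of this change.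

Compound 2 `Cc1nn(-c2ccccc2)c(Sc2ccc(-c3nc4cc([N+](=O)[O-])ccc4[nH]3)cc2)c1/C=N/NC(N)=O` carries a second core; the difference between the two cores is not broken down here. In this assay compound 2 gives 16600 nM, a value that sits with those of compound 1 and compound 3 inside the usual scatter, so no order among the three is claimed.

Compound 4 `Cc1nn(-c2ccccc2)c(Sc2ccc(-c3nc4cc(C(=O)O)ccc4[nH]3)cc2)c1/C=N/NC(N)=O` is not yet measured. It differs from compound 2 in carboxy in place of nitro on an aromatic carbon, which is the same change as that from compound 1 to compound 3, at the same place on the ring. Because the measured instance of this change read a 1.4-fold higher number from compound 1 to compound 3 (0.16 log units; within the scatter), a step of similar size is expected from compound 2 to compound 4, namely a 1.3-fold higher number from compound 2 to compound 4 (0.10 log units; within the scatter); this rests on a single pair and on a starting value for compound 2 of 16600 nM, so the range kept around it is wide. Compound 4 is therefore estimated at 21000 nM in this assay, expected to fall between 9000 nM and 50000 nM.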

Compound 4, concentration for 50% growth inhibition: 13600 nM
Compound 4: middle estimate off by 1.5-fold (0.19 log units), on the high side; the measured number falls inside the stated range.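

In this assay, carboxy in place of nitro on the second core gives a 1.2-fold lower number from compound 2 to compound 4 (0.09 log units; within the scatter). The two instances of the change do not separate from each other: the same change on two cores in this assay, a 1.4-fold higher number (0.16 log units; within the scatter) from compound 1 to compound 3 and a 1.2-fold lower number (0.09 log units; within the scatter) from compound 2 to compound 4, 1.8-fold (0.24 log units) apart, within the scatter of two such steps. The exchange of 5-nitro-1H-benzimidazol-2-yl for 5-carboxy-1H-benzimidazol-2-yl therefore has no measurable effect on either core, and no difference between the cores in their response to it can be seen; this does not show that the cores would respond alike to a change with a larger effect, and two pairs set no rule for the wider series.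

The compounds shown carry only nitro or carboxy on this aromatic carbon, so it remains open whether another group there, such as an amine or a nitrile, would give a step beyond the scatter on either core. Also open is how each of the places in which the two cores differ bears on growth inhibition, since no pair shown changes any of them alone.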